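This account rests on a few compounds, and the source may have more. Where it says the series, first, only, none or still open, it means among the compounds named here.

Measured so far in a physicochemical assay for solubility, in phosphate buffer, at pH 6.5; a higher number here means a more soluble compound, a lower number a less soluble compound: compound 1 `C=C[C@@H]1C[C@]1(NC(=O)[C@@H]1C[C@@H](Oc2nccc3cc(OC)ccc23)CN1C(=O)[C@@H](NC(=O)N[C@@H](C)COC)C(C)(C)C)C(=O)NS(=O)(=O)C1CC1` gives 1070 ug/mL; compound 2 `C=C[C@@H]1C[C@]1(NC(=O)[C@@H]1C[C@@H](Oc2nccc3cc(OC)ccc23)CN1C(=O)[C@@H](NC(=O)N[C@H](COC)C(C)C)C(C)(C)C)C(=O)NS(=O)(=O)C1CC1` gives 570 ug/mL; compound 3 `C=C[C@@H]1C[C@]1(NC(=O)[C@@H]1C[C@@H](Oc2nccc3cc(OC)ccc23)CN1C(=O)[C@@H](NC(=O)N[C@H](COC)c1ccccc1)C(C)(C)C)C(=O)NS(=O)(=O)C1CC1` gives 259 ug/mL.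

Compound 1 stands highest of the three numbers: its nearest neighbour is compound 2, a 1.9-fold lower number from compound 1 to compound 2 (0.27 log units; within the scatter), and its furthest is compound 3, a 4.1-fold lower number from compound 1 to compound 3 (0.62 log units; beyond the scatter). Compound 4 `C=C[C@@H]1C[C@]1(NC(=O)[C@@H]1C[C@@H](Oc2nccc3cc(OC)ccc23)CN1C(=O)[C@@H](NC(=O)N[C@H](C(=O)O)C(C)(C)C)C(C)(C)C)C(=O)NS(=O)(=O)C1CC1` differs from compound 1 in this way: 1-carboxy-2,2-dimethylpropyl in place of 1-(methoxymethyl)ethyl on an amide-type nitrogen. Among the measured compounds shown here, none of the measured steps tracks this change closely; they swap methyl for isopropyl or phenyl while keeping the methoxymethyl arm, the largest among them being a 4.1-fold lower number from compound 1 to compound 3 (0.62 log units; beyond the scatter). Compound 4 brings in a carboxy group instead, a change not represented here, so the expected step is a 1.7-fold higher number from compound 1 to compound 4 (0.23 log units; within the scatter), held with wide uncertainty. In this assay compound 4 is estimated at 1800 ug/mL, within a range of 500 ug/mL to 6000 ug/mL.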

Compound 4, solubility: > 1160 ug/mL
Compound 4: only a limit was reported; the forecaster's own chance of this, stated with the estimate: 5%; the middle value is on the limit's open side.
By their numbers in this assay, from the lowest: compound 3; then compounds 2 and 1 (each within the scatter of the next). At a limit, above all of these: compound 4.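

In this assay compound 4 gives > 1160 ug/mL as a limit of the assay and not as a number. The earlier compounds shown here all kept the methoxymethyl arm, and compound 4 shows that 1-carboxy-2,2-dimethylpropyl can replace it on the amide-type nitrogen with no fall in the number: the floors an at least 1.0-fold higher number from compound 1 to compound 4 (0.03 log units; that floor lies within the scatter) and an at least 2.0-fold higher number from compound 2 to compound 4 (0.30 log units; that floor lies within the scatter) both lie within the scatter. Only the floor an at least 4.4-fold higher number from compound 3 to compound 4 (0.65 log units; beyond the scatter) clears the scatter, so this larger group, unlike the phenyl-bearing one, keeps the number high.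

How far compound 4 truly lies from compound 1 stays hidden behind the limit. Also open, from the compounds shown here alone, is whether an amine or a methyl ester on the same nitrogen would give a similar number.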